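A few compounds are considered here, and "the series" means these few. Any claim that something is new, unique, unknown or untested is made for them only; others in the source may bear on it.

Values measured so far in a functional assay on MCF7 cells (Homo sapiens) for antiproliferative activity, read by MTT assay, with a stated time of 72 h; a higher number here means a weaker inhibitor, a lower number a stronger inhibitor
- compound 1 `O=S1(=O)C=Cc2cccc(Nc3ccc(OC(F)(F)F)cc3)c21` gives 2690 nM
- compound 2 `O=S1(=O)C=Cc2cccc(Nc3ccc(Cl)cc3)c21` gives 680 nM
- compound 3 `Cc1ccc(Nc2cccc3c2S(=O)(=O)C=C3)cc1` gives 1890 nM

Compound 2 has the lowest number of the three, and its steps to both others lie beyond the scatter. Compound 4 `O=S1(=O)C=Cc2cccc(Nc3ccc(Cl)c(Cl)c3)c21` has not yet been measured. It differs from compound 2 by chloro in place of hydrogen on an aromatic carbon, ortho to a chloro group and meta to a large group, counted in full as chloro in place of hydrogen on an aromatic carbon and with nothing else changed.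

Among the compounds with values here, no measured step adds a group at this place, so the evidence is indirect. Within the data shown here, the three steps all exchange the single group already on that ring. Chloro in place of trifluoromethoxy gave a 4.0-fold lower number from compound 1 to compound 2 (0.60 log units; beyond the scatter) and methyl in place of chloro gave a 2.8-fold higher number from compound 2 to compound 3 (0.44 log units; beyond the scatter) while methyl in place of trifluoromethoxy gave a 1.4-fold lower number from compound 1 to compound 3 (0.15 log units; within the scatter) in this assay without a change beyond the scatter. These steps are modest at their largest, and the two beyond the scatter both favour chloro. A modest step towards a lower number is therefore expected in this assay, though it may stay within the scatter. The estimated step is a 1.4-fold lower number from compound 2 to compound 4 (0.15 log units; within the scatter) and remains an expectation. For compound 4 the estimated value is 480 nM with an expected range from 170 nM to 1400 nM until it is measured.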

Compound 4, half-maximal inhibitory concentration: 570 nM
For compound 4 the middle estimate is 1.2-fold (0.07 log units) below the measured one, within the range that was stated.
By their numbers in this assay, from the lowest: compounds 4 and 2 (each within the scatter of the next); then compounds 3 and 1 (each within the scatter of the next).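

In this assay, chloro in place of hydrogen on an aromatic carbon, ortho to a chloro group and meta to a large group, gave a 1.2-fold lower number from compound 2 to compound 4 (0.08 log units; within the scatter). Within the data shown here, the earlier steps only exchanged the single group already on that ring, so this is the first reading at a further ring carbon, and it shows that a second chloro can be carried there with no change beyond the scatter. The result therefore keeps compound 4 level with compound 2, the compound whose steps to compound 1 and compound 3 both lay beyond the scatter, and no measurement in hand bears on what lies behind this reading.

Going by these compounds, what a methyl, a methoxy group, an amine or a carboxylic acid would give at this same ring carbon remains open, since one chloro cannot show how far the position accepts other groups. On these data alone, it also remains open whether a chloro added here would read the same with trifluoromethoxy or methyl as the existing group, as in compound 1 and compound 3.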